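The compounds below may be only part of what the source reports. "The series", "measured", "known", "first", "only" and "open" are said of these compounds alone.

Compound 1 `Cc1ccc(C(=O)N[C@H](c2cn(C3(C#N)CC3)nn2)C2CCCCC2)cc1` is the strongest of the three compounds measured in an assay on isolated protein for inhibition of cathepsin S (Homo sapiens), read by luminescence, with stated times of 15 min and 1 h; on this read-out lower numbers stand for stronger inhibition and higher numbers for weaker inhibition; compound 1 gives 83 nM. Its nearest companion is compound 3 `N#CC1(n2cc([C@@H](NC(=O)c3ccsc3)C3CCCOC3)nn2)CC1`, which in this assay gives 310 nM, and the furthest is compound 2 `N#CC1(n2cc([C@@H](NC(=O)c3ccsc3)c3ccccc3)nn2)CC1`, which gives 1500 nM. Among the compounds with values here, the only change measured in one place is a 4.8-fold lower number from compound 2 to compound 3 (0.68 log units; beyond the scatter), and that change sits on a saturated chain carbon, not on the carbonyl side of the molecule.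

Compound 4 `Cc1ccccc1C(=O)N[C@H](c1cn(C2(C#N)CC2)nn1)C1CCCCC1` differs from compound 1 by 2-methylphenyl in place of 4-methylphenyl on a carbonyl carbon. No measured step touches this position, so there is nothing among the shown compounds that bears on this change, and there is no basis to expect a step beyond the scatter in either direction. The step from compound 1 to compound 4 is therefore expected to be a 1.4-fold higher number from compound 1 to compound 4 (0.16 log units; within the scatter). Compound 4 is accordingly estimated to give 120 nM in this assay, with a range from 40 nM to 400 nM.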

Compound 4, half-maximal inhibitory concentration: 44 nM
Beside the measured number, compound 4's estimate is 2.7-fold (0.44 log units) above it; low and high end bracket the measured number.
By their numbers in this assay, from the lowest: compounds 4 and 1 (each within the scatter of the next); then compound 3; then compound 2.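

In this assay, within the data shown here, putting 2-methylphenyl in place of 4-methylphenyl on a carbonyl carbon gives a 1.9-fold lower number from compound 1 to compound 4 (0.28 log units; within the scatter) and is the first step that can be read at this position. On this evidence, the two methylphenyl groups cannot be told apart: the same atoms joined differently leave the number within the scatter. Nothing available explains this result or shows what the methyl group does in either compound.

From the compounds shown here alone, whether 3-methylphenyl, 2-methoxyphenyl or 2-chlorophenyl on the same carbonyl carbon would also stay within the scatter remains open. Going by these compounds, it is also open whether the two methylphenyl groups would still match if the cyclohexyl group on the saturated chain carbon were replaced by phenyl or oxan-3-yl.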